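Extending a Chain in a Cytotoxicity Series

A few compounds are considered here, and "the series" means these few. Any claim that something is new, unique, unknown or untested is made for them only; others in the source may bear on it.

Of the compounds shown here, two have been measured so far in a functional assay on A549 cells (Homo sapiens) for cytotoxicity, read by MTT assay, with a stated time of 24 h, tested at 10 uM; on this read-out higher numbers stand for a weaker effect at the one concentration tested and lower numbers for a stronger effect. Compound 2 `CCCCCCCCCCOC(=O)CCC(=O)N1CCN(CCCOc2cc3c(Nc4ccc(F)c(Cl)c4)ncnc3cc2OC)CC1` gives 95.7%, the higher of the two numbers, while compound 1 `CCCCCCOC(=O)CCC(=O)N1CCN(CCCOc2cc3c(Nc4ccc(F)c(Cl)c4)ncnc3cc2OC)CC1` gives 89.3%. The two values sit within the usual scatter of each other, so no order between them can be claimed. For the measured compounds named here, the one step measured between them is a number 6.4 percentage points higher from compound 1 to compound 2 (within the scatter), a change that puts butyl in place of hydrogen on a saturated chain carbon.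

Compound 3 `CCCCCCCCCCCCCCCOC(=O)CCC(=O)N1CCN(CCCOc2cc3c(Nc4ccc(F)c(Cl)c4)ncnc3cc2OC)CC1` has not yet been measured. It differs from compound 2 by pentyl in place of hydrogen on a saturated chain carbon, ten or more bonds along the chain from an oxygen next to a carbonyl group. Going by the values given here, the only measured step that bears on this change is the one from compound 1 to compound 2, which also replaced a hydrogen on a saturated chain carbon with a longer group and stayed within the scatter. Because a number 6.4 percentage points higher from compound 1 to compound 2 (within the scatter) gave no movement beyond the scatter, compound 3 is expected to show a number 0.3 percentage points higher from compound 2 to compound 3 (within the scatter). In this assay compound 3 is therefore estimated to give 96%, with a range from 84% to 106%.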

Compound 3, a percentage reported as activity, at one concentration (the size of the read-out at that concentration, not a potency): 92%
For compound 3 the middle estimate is 4 percentage points above the measured one; the measured number falls inside the stated range.
By their numbers in this assay, from the lowest: compounds 1, 3 and 2 (each within the scatter of the next).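

The new compound extends the finding further out along the chain. In this assay, pentyl in place of hydrogen on a saturated chain carbon, ten or more bonds along the chain from an oxygen next to a carbonyl group, gives a number 3.7 percentage points lower from compound 2 to compound 3 (within the scatter), and the larger change, nonyl in place of hydrogen, six bonds along the chain from that oxygen, gives a number 2.7 percentage points higher from compound 1 to compound 3 (within the scatter). All three steps among these compounds now stay within the scatter and none goes against that, so adding carbons at these two places has no readable effect on this read-out, and no other measurement here helps to interpret these numbers.

All three compounds carry a plain saturated chain on the ester, so the compounds shown leave open whether a much shorter chain, such as methyl or ethyl, would give a number beyond the scatter. The same holds for a chain ending in an amine or a carboxylic acid, which could show whether this position responds to anything other than added carbons.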